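Swapping the aryl group on the piperazine nitrogen

The compounds below may be only part of what the source reports. "The series", "measured", "known", "first", "only" and "open" are said of these compounds alone.

Compound 1 `Cc1ccc(N2CCN(C(=O)c3oc(C)nc3-c3ccccc3)CC2)c(C)c1` is measured in a functional assay on HL-60 cells (Homo sapiens) for inhibition, read by MTT assay, with a stated time of 72 h (on this read-out lower numbers stand for stronger inhibition and higher numbers for weaker inhibition), where compound 1 gives 101 nM. This is the highest of the two numbers shown; compound 2 `Cc1nc(-c2cccc(F)c2)c(C(=O)N2CCN(c3cc(Cl)cc(Cl)c3)CC2)o1` gives 41.7 nM in this assay, a gap beyond the scatter. Compound 3 `Cc1nc(-c2ccccc2)c(C(=O)N2CCN(c3ccc(F)cc3)CC2)o1` has not yet been measured. It differs from compound 1 in one place: 4-fluorophenyl in place of 2,4-dimethylphenyl on an amine nitrogen in a ring. Among the measured compounds shown here, no comparable step between measured compounds is available, so the expected step of a 1.3-fold lower number from compound 1 to compound 3 (0.10 log units; within the scatter) is small and could well stay within the scatter. Compound 3 is expected to give about 80 nM in this assay, within a range from 30 nM to 250 nM.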

Compound 3, half-maximal inhibitory concentration: > 1000 nM
Compound 3: only a limit was reported; the forecaster's own chance of this, stated with the estimate: 5%; middle value at least 12-fold (1.09 log units) away from the limit.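

On an amine nitrogen in a ring, 4-fluorophenyl in place of 2,4-dimethylphenyl gives an at least 9.9-fold higher number from compound 1 to compound 3 (0.99 log units; beyond the scatter) in this assay. This position is therefore sensitive to the choice of aryl group, even though each group is one six-membered aromatic ring of carbon only. The step is a minimum rather than an exact size because compound 3 is reported only as a limit: the limit of > 1000 nM in this assay, at which 1 of the 3 values shown sits.

On these data alone, the fluorine and the two methyl groups change together, so their separate contributions remain open. As far as these compounds go, whether a methoxy group on this phenyl ring would keep the number of compound 1 also remains open.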